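The compounds below may be only part of what the source reports. "The series", "measured", "known", "first", "only" and "open" are said of these compounds alone.

Within the data shown here, in a functional assay (plasma) for inhibition, with Homo sapiens as the target (on this read-out lower numbers stand for stronger inhibition and higher numbers for weaker inhibition), compound 3 (`O=C(O)CCC/C=C\CC1C2CCC(O2)C1COCC1CCCCC1`) gives 165000 nM, and this is its only number, since its two further entries carry no single figure. That number is higher than every entry for its two relatives. Compound 1 (`CCCCCCOC[C@@H]1C2CCC(O2)[C@H]1C/C=C\CCCC(=O)O`) gives 25000 nM; 18000 nM; 500 nM (3 entries), a wide spread, and compound 2 (`CCCCCCOC[C@@H]1C2CCC(O2)[C@@H]1C/C=C\CCCC(=O)O`) gives 38500 nM; 10000 nM (2 entries). Both of these carry an open hexyl chain where compound 3 carries its cyclohexylmethyl group.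

Among the measured compounds shown here, the next compound, compound 4 (`CCCC#CCOCC1C2CCC(O2)C1C/C=C\CCCC(=O)O`), keeps the shared core and changes only that group, with pent-1-yn-1-yl in place of cyclohexyl on a saturated chain carbon bound to an oxygen on a saturated carbon. Cut one bond further out, the same change reads cyclohexylmethyl to hex-2-yn-1-yl, so compound 4 also has an open chain.

For the measured compounds named here, no two measured compounds differ in one place only, so no direct step can serve as a guide. The closest comparison is with the open-chain compound 2 at 38500 nM; 10000 nM (2 entries), and with compound 1 at 25000 nM; 18000 nM; 500 nM (3 entries). On that basis, the expected change is a 5.5-fold lower number from compound 3 to compound 4 (0.74 log units; beyond the scatter), a move towards stronger inhibition that is estimated to exceed the usual scatter. For compound 4 the estimated value is 30000 nM, with an expected range of 5000 nM to 150000 nM.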

Compound 4, half-maximal inhibitory concentration: 200 nM
Estimate against measurement, compound 4: 150-fold (2.18 log units) above, outside the stated range (below it).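

In this assay, among these compounds, putting pent-1-yn-1-yl in place of cyclohexyl, on a saturated chain carbon bound to an oxygen on a saturated carbon, gives an 830-fold lower number from compound 3 to compound 4 (2.92 log units; beyond the scatter), and this is the first step that can be read between two compounds differing in one place. It shows that this position is far from indifferent: with the rest of the molecule unchanged, exchanging a ring of carbon for an open chain holding a triple bond moves the number well beyond the usual scatter. The exact size of the step still calls for caution, since entries for one and the same compound can lie far apart in this assay: the several entries of compound 1 in this assay, 25000 nM; 18000 nM; 500 nM (3 entries)

The change removes a ring and brings in a triple bond at once, so this single step cannot tell which of the two carries the effect, and a saturated hexyl group on the same drawn core would be needed to separate them. Also open, as far as these compounds go, is how a phenyl ring or a longer alkynyl chain would behave at this position, and whether the effect holds when the configuration of the core is defined.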